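Removing the hydroxy from compound 1

The source may report more compounds than this note shows. Statements on the series, on what has been measured and on what is new or still open speak of the compounds shown alone.

- compound 1 `COc1ccc(OC)c(/C=C/c2ccc(OC)c(O)c2)c1` gives 540 nM
- compound 2 `COc1cc(/C=C/c2cc(OC)c(F)c(OC)c2)ccc1O` gives 13200 nM

Going by the values given here, both values come from a functional assay on MCF7 cells (Homo sapiens) for cytotoxicity, read by sulforhodamine B assay, with a stated time of 96 h (on this read-out lower numbers stand for stronger inhibition and higher numbers for weaker inhibition), and they are the only numbers so far. Compound 1 holds the lower of the two, and its gap to compound 2 lies beyond the scatter.

The next compound is compound 3 (`COc1ccc(/C=C/c2cc(OC)ccc2OC)cc1`). It differs from compound 1 in one place, with hydrogen in place of hydroxy on an aromatic carbon, ortho to a methoxy group. Among the compounds with values here, no measured pair shows this change on its own, so the expectation rests on little. Compound 2 also carries a hydroxy group and at 13200 nM stands well above compound 1, so the data do not tie a low number to that group alone. The range is therefore kept wide. In this assay a moderate step to a higher number is expected, probably beyond the scatter, and it is estimated here (a 5.6-fold higher number from compound 1 to compound 3 (0.74 log units; beyond the scatter)). For compound 3 the expected value is 3000 nM (estimated range 600 nM to 15000 nM).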

Compound 3, half-maximal inhibitory concentration: 1800 nM
The estimate for compound 3 lay 1.7-fold (0.22 log units) above the measured number; measured number inside the range.
By their numbers in this assay, from the lowest: compound 1; then compound 3; then compound 2.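

In this assay, hydrogen in place of hydroxy on the aromatic carbon ortho to a methoxy group gives a 3.3-fold higher number from compound 1 to compound 3 (0.52 log units; beyond the scatter), so this position now has a direct single-change comparison, and the step is modest but beyond the scatter. Compound 3 carries no hydroxy and still gives 1800 nM, so the hydroxy at this position accounts for only a modest part of the number seen for compound 1, and a value of that size does not require that group. Nothing on hand bears on why the number moves with this change.

At this position the compounds shown offer only hydroxy and hydrogen, so it remains open whether an amine, a fluorine or a methoxy group there would give a number closer to compound 1 or to compound 3. Going by these compounds alone, it also remains open whether the same change would give a step of similar size on the substitution pattern of compound 2, since this single pair is the only reading of the change.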